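Changing the group on compound 3's aromatic carbon

This account rests on a few compounds, and the source may have more. Where it says the series, first, only, none or still open, it means among the compounds named here.

Measured in a functional assay on Jurkat cells (Homo sapiens) for antiproliferative activity, read by MTT assay, with a stated time of 72 h; on this read-out higher numbers stand for weaker inhibition and lower numbers for stronger inhibition:
Compound 1 `COc1cc(C(=O)c2sc3ccccc3c2-c2ccccc2)cc(OC)c1OC`: 1500 nM
Compound 2 `COc1ccc(-c2c(C(=O)c3cc(OC)c(OC)c(OC)c3)sc3ccccc23)c(OC)c1`: 4000 nM
Compound 3 `COc1ccc(OC)c(-c2c(C(=O)c3cc(OC)c(OC)c(OC)c3)sc3ccccc23)c1`: > 10000 nM, a limit and not a number

Compound 3 sits at the limit of > 10000 nM in this assay, at which 1 of the 3 values shown sits, and its steps from compound 1 and compound 2 are both beyond the scatter. Compound 4 `COc1ccc(Nc2c(C(=O)c3cc(OC)c(OC)c(OC)c3)sc3ccccc23)cc1` differs from it by (4-methoxyphenyl)amino in place of 2,5-dimethoxyphenyl on an aromatic carbon. In words, it carries (4-methoxyphenyl)amino in place of 2,5-dimethoxyphenyl on an aromatic carbon.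

Within the data shown here, three measured steps concern that same carbon. Placing 2,4-dimethoxyphenyl there in place of phenyl gave a 2.7-fold higher number from compound 1 to compound 2 (0.43 log units; beyond the scatter). Placing 2,5-dimethoxyphenyl there in place of phenyl gave an at least 6.6-fold higher number from compound 1 to compound 3 (0.82 log units; beyond the scatter). The two dimethoxyphenyl groups are separated by an at least 2.5-fold higher number from compound 2 to compound 3 (0.39 log units; beyond the scatter). So the group at this carbon does move the number, but no measured compound carries the amino link, which leaves the size of the step uncertain.

Since compound 4 gives up the 2,5-dimethoxyphenyl group of compound 3, a modest move in this assay towards stronger inhibition is expected. The expected change is an at least 4.0-fold lower number from compound 3 to compound 4 (0.60 log units; beyond the scatter). Compound 4 is estimated at 2500 nM, with an expected range from 400 nM to 10000 nM.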

Compound 4, half-maximal inhibitory concentration: 3500 nM
Beside the measured number, compound 4's estimate is 1.4-fold (0.15 log units) below it; low and high end bracket the measured number.
By their numbers in this assay, from the lowest: compound 1; then compounds 4 and 2 (each within the scatter of the next). At a limit, above all of these: compound 3.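

In this assay, the amino link at this carbon gives a result that cannot be told apart from that of 2,4-dimethoxyphenyl, with a 1.1-fold lower number from compound 2 to compound 4 (0.06 log units; within the scatter). Against phenyl, however, the change is a modest loss, with a 2.3-fold higher number from compound 1 to compound 4 (0.37 log units; beyond the scatter), so (4-methoxyphenyl)amino does not match the phenyl of compound 1. Replacing 2,5-dimethoxyphenyl gives an at least 2.8-fold lower number from compound 3 to compound 4 (0.45 log units; beyond the scatter), and compound 3 stands at a limit and not a number: the limit of > 10000 nM in this assay, at which 1 of the 4 values shown sits.

Going by these compounds, what a plain phenylamino group or a 4-methoxyphenyl group joined directly to this carbon would give remains open, and with it whether the amino link or the methoxy group sets this level. Also open, on these data alone, is how a longer link, such as a benzylamino group, would compare.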